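Dimethoxy substitution on the benzylamine end of the series

The source may hold more compounds than are shown below. What is called first, only, known or untested is meant among the compounds shown, and "the series" means these compounds.

Values in a functional assay (aorta) with Rattus norvegicus as the target (on this read-out higher numbers stand for weaker inhibition and lower numbers for stronger inhibition), so far:
- compound 1 `CC(C)c1cn2ccccc2c1S(=O)(=O)c1ccc(OCCCNCc2ccccc2)cc1` gives 22.8 nM
- compound 2 `CC(C)c1cn2ccccc2c1S(=O)(=O)c1ccc(OCCCN2CCN(c3ccccc3)CC2)cc1` gives 205 nM
- compound 3 `COc1ccc(CN(C)CCCOc2ccc(S(=O)(=O)c3c(C(C)C)cn4ccccc34)cc2)cc1OC` gives 3.18 nM
- compound 4 `COc1ccc(CNCCCOc2ccc(S(=O)(=O)c3c(C(C)C)cn4ccccc34)cc2)cc1OC` has no value yet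

Compound 1 stands in the middle of the three numbers, with compound 3 lower and compound 2 higher. The change to compound 4 is 3,4-dimethoxyphenyl in place of phenyl on a saturated chain carbon bound to an amine nitrogen and nothing else differs. Among the measured compounds shown here, the only measured step, a 9.0-fold higher number from compound 1 to compound 2 (0.95 log units; beyond the scatter), exchanges the whole amine, so it is a loose guide that shows only that this end can shift the number beyond the scatter. Compound 3 gives 3.18 nM and carries the same 3,4-dimethoxyphenyl, with an extra methyl group relative to compound 4. A moderate move towards a lower number in this assay is therefore expected. The expected change is a 2.9-fold lower number from compound 1 to compound 4 (0.45 log units; beyond the scatter) and remains an estimate. For compound 4 the estimated value is 8 nM with an expected range of 2 nM to 30 nM for now.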

Compound 4, half-maximal inhibitory concentration: 13 nM
For compound 4 the middle estimate is 1.6-fold (0.21 log units) below the measured one; the range from low to high includes it.
By their numbers in this assay, from the lowest: compound 3; then compounds 4 and 1 (each within the scatter of the next); then compound 2.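

In this assay, 3,4-dimethoxyphenyl in place of phenyl does not by itself separate the two secondary amines, with a 1.8-fold lower number from compound 1 to compound 4 (0.24 log units; within the scatter) as the step. The methyl group on the amine nitrogen matters more at this end of the series, since a 4.1-fold higher number from compound 3 to compound 4 (0.61 log units; beyond the scatter) is the step for its removal. The benzylamine type of end also keeps its advantage over 4-phenylpiperazin-1-yl once the dimethoxy groups are present, with a 16-fold lower number from compound 2 to compound 4 (1.20 log units; beyond the scatter) as the step.

As far as these compounds go, whether an ethyl group on the amine nitrogen or a longer chain would extend the methyl result remains open. Nothing available bears on the origin of these steps.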